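A few compounds are considered here, and "the series" means these few. Any claim that something is new, unique, unknown or untested is made for them only; others in the source may bear on it.

Working notes on the series, read in an ADME assay on Akata cells (Homo sapiens) for cytotoxicity, with a stated time of 7 days; on this read-out lower numbers stand for higher toxicity in this test and higher numbers for lower toxicity in this test. Compound 1 `CN(C)c1nc(N)nc2c1ncn2/C=C1/CC1(CO)CO` gives > 24000 nM, which is a limit and not a number. Compound 2 `Nc1nc(NC2CCCC2)c2ncn(/C=C3/CC3(CO)CO)c2n1` gives > 20000 nM, also a limit, so compound 2 has no exact position on the scale. The next change leads to compound 3 `CCCCCCSc1nc(N)nc2c1ncn2/C=C1/CC1(CO)CO`: hexylsulfanyl in place of cyclopentylamino on an aromatic carbon. Among the measured compounds shown here, only one measured step bears on this change, a step that the two limits leave unreadable from compound 1 to compound 2, where cyclopentylamino took the place of dimethylamino on an aromatic carbon. Its size cannot be read, and neither measured compound carries hexylsulfanyl. No step beyond the scatter is therefore expected in this assay, and no direction is favoured with confidence. The expected step is an at least 1.3-fold lower number from compound 2 to compound 3 (0.12 log units; that floor lies within the scatter), an estimate with wide uncertainty. For compound 3 the estimated value is 15000 nM, with an expected range of 4000 nM to 40000 nM.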

Compound 3, half-maximal cytotoxic concentration: > 20000 nM
Compound 3: a limit, no number; the forecaster's own chance of this, stated with the estimate: 45%; middle value at least 1.3-fold (0.12 log units) away from the limit.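

In this assay, among the compounds shown here, compound 3 gives > 20000 nM, a limit and not a number, so no step linking compound 3 with compound 1 or compound 2 can be read. The compounds shown leave open where any of the three sits on the scale, and whether dimethylamino, cyclopentylamino and hexylsulfanyl differ at all in this read-out.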